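Quinoline diamines: cytotoxicity on HepG2 cells

The source may hold more compounds than are shown below. What is called first, only, known or untested is meant among the compounds shown, and "the series" means these compounds.

Measured compounds:
Compound 1 `COc1cccc(Oc2ccc3c(NCCCNCc4cc(F)ccc4OC)ccnc3c2)c1` 7100 nM
Compound 2 `Fc1ccc(Oc2ccc3c(NCCCNCc4ccco4)ccnc3c2)cc1` 16000 nM
Compound 3 `COc1cccc(Oc2ccc3c(NCCCNCc4cccc(OC)c4O)ccnc3c2)c1` 5300 nM

In an ADME assay on HepG2 cells (Homo sapiens) for cytotoxicity, read by luminescence, CellTiter-Glo and ATP content, with a stated time of 72 h (a higher number here means that more compound is needed for the effect, a lower number that less compound is needed), compound 1 stands second highest of the three numbers. Its nearest neighbour is compound 3, reached by a 1.3-fold lower number from compound 1 to compound 3 (0.13 log units; within the scatter), the change sitting on the amine side of the chain. Compound 2 differs from compound 1 in two places, so only its value can be compared: it gives a higher number than compound 1.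

Compound 4 `COc1ccc(F)cc1CNCCCNc1ccnc2cc(Cc3ccccc3)ccc12` is not yet measured. It differs from compound 1 by benzyl in place of 3-methoxyphenoxy on an aromatic carbon. Within the data shown here, no measured step touches this part of the shared core: the one step on record, from compound 1 to compound 3, lies on the other end of the molecule and is within the scatter, and compound 2 changes two places at once. There is therefore nothing to anchor a direction, and the expected step is estimated as a 1.0-fold lower number from compound 1 to compound 4 (0.01 log units; within the scatter), no change beyond the scatter in this assay. Compound 4 is estimated at 7000 nM, with a range of 3000 nM to 17000 nM.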

Compound 4, half-maximal effective concentration: 7990 nM
Compound 4: the middle estimate sits 1.1-fold (0.06 log units) below what was measured, and the stated range covers the measured number.
By their numbers in this assay, from the lowest: compounds 3, 1, 4 and 2 (each within the scatter of the next, the first and the last beyond it).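

Among these compounds, this is the first measured step at this aromatic carbon of the shared core: in this assay, a 1.1-fold higher number from compound 1 to compound 4 (0.05 log units; within the scatter), with benzyl in place of 3-methoxyphenoxy. The swap removes the hydrogen-bond acceptors counted on the leaving group and leaves a six-membered aromatic ring of carbon only, yet the two numbers stay within the scatter, so in this one pair the cytotoxicity read-out does not separate the two groups. Nothing measured here gives a reason for this result.

The compounds shown leave open whether a group without an aromatic ring at this carbon, such as morpholine or a single chlorine atom, would also stay within the scatter. They also leave open whether benzyl gives the same reading alongside the 2-hydroxy-3-methoxyphenyl group of compound 3.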